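Regaining an aromatic ring on the nitrogen side chain

The source may report more compounds than this note shows. Statements on the series, on what has been measured and on what is new or still open speak of the compounds shown alone.

- compound 1 `COC(=O)C(Nc1cc(CS(=O)(=O)/C=C/c2c(OC)cc(OC)cc2OC)ccc1OC)c1ccc(Br)cc1`: 200 nM
- compound 2 `COc1cc(OC)c(/C=C/S(=O)(=O)Cc2ccc(OC)c(NCCC(=O)O)c2)c(OC)c1`: 5000 nM

In a functional assay on K562 cells (Homo sapiens) for cytotoxicity, read by trypan blue exclusion, with a stated time of 96 h (a higher number here means a weaker inhibitor, a lower number a stronger inhibitor), compound 2 stands highest of the two at 5000 nM. Compound 3 `COc1cc(OC)c(/C=C/S(=O)(=O)Cc2ccc(OC)c(NC(C(=O)O)c3ccc(Cl)cc3)c2)c(OC)c1` differs from it in one place: carboxy(4-chlorophenyl)methyl in place of 2-carboxyethyl on a nitrogen on an aromatic ring. For the measured compounds named here, the one measured step that bears on this is a 25-fold higher number from compound 1 to compound 2 (1.40 log units; beyond the scatter), a large one, in which a group holding an aromatic ring gave way to 2-carboxyethyl. Compound 3 again carries a six-membered aromatic ring there but keeps a carboxy group, so only part of that step is expected to reverse. The expected change is a 7.1-fold lower number from compound 2 to compound 3 (0.85 log units; beyond the scatter). For compound 3 the estimated value is 700 nM, within a range of 150 nM to 3000 nM.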

Compound 3, half-maximal inhibitory concentration: 250 nM
Beside the measured number, compound 3's estimate is 2.8-fold (0.45 log units) above it; the range from low to high includes it.
By their numbers in this assay, from the lowest: compounds 1 and 3 (each within the scatter of the next); then compound 2.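

Putting carboxy(4-chlorophenyl)methyl on this nitrogen gives a 20-fold lower number from compound 2 to compound 3 (1.30 log units; beyond the scatter), so the carboxy group of compound 2 does not by itself go with a high number, as compound 3 also carries one. The other comparison gives a 1.3-fold higher number from compound 1 to compound 3 (0.10 log units; within the scatter), so the methoxycarbonyl group of compound 1 is not required for a low number here. No measurement shown explains either step.

On these data alone, it remains open whether the aromatic ring itself or its chlorine matters more, which a plain phenyl ring could help separate. As far as these compounds go, how an amide in place of the carboxy group would read is also open.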